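Swapping a pyridine for a methylfuran on a shared core

A few compounds are considered here, and "the series" means these few. Any claim that something is new, unique, unknown or untested is made for them only; others in the source may bear on it.

Measured so far:
- compound 1, `Clc1ccc(-c2cc(-c3cccnc3)nc(-c3ccsc3)c2)o1`: 21600 nM
- compound 2, `Clc1ccc(-c2cc(-c3ccoc3)cc(-c3cccs3)n2)cc1`: 21100 nM
- compound 3, `Clc1ccc(-c2cc(-c3cccnc3)nc(-c3cccs3)c2)o1`: 13000 nM

All three compounds were tested in a functional assay on DU-145 cells (Homo sapiens) for cytotoxicity, in the presence of a further agent that is not named here; a lower number here means a stronger inhibitor, a higher number a weaker inhibitor. On the numbers shown, compound 1 stands at the top of the three, but its gap to compound 2 is within the scatter, and the only step that can be computed, a 1.7-fold lower number from compound 1 to compound 3 (0.22 log units; within the scatter), is within the scatter as well; that step concerns a thiophene group and not the part of the molecule that changes here.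

Compound 4, `Cc1ccc(-c2cc(-c3ccc(Cl)o3)cc(-c3ccsc3)n2)o1`, has not been measured. It differs from compound 1 in one place: 5-methylfuran-2-yl in place of pyridin-3-yl on an aromatic carbon

Among the compounds with values here, no measured pair isolates this exchange of a pyridin-3-yl for a 5-methylfuran-2-yl group, and the one computed step does not touch it. The expectation therefore rests on the three measured numbers alone, which all sit close together. For compound 4 the expected step in this assay is a 1.1-fold lower number from compound 1 to compound 4 (0.03 log units; within the scatter), which is no step beyond the scatter. Compound 4 is estimated at 20000 nM in this assay. The low end of that estimate for compound 4 is 7000 nM. The high end of that estimate for compound 4 is expected at 55000 nM.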

Compound 4, half-maximal inhibitory concentration: 18500 nM
Beside the measured number, compound 4's estimate is 1.1-fold (0.03 log units) above it, and the stated range covers the measured number.
By their numbers in this assay, from the lowest: compounds 3, 4, 2 and 1 (each within the scatter of the next).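

Within the data shown here, until now the only step that could be read concerned a thiophene group, not this position. Here, in this assay, replacing the pyridin-3-yl group next to the ring nitrogen with 5-methylfuran-2-yl gives a 1.2-fold lower number from compound 1 to compound 4 (0.07 log units; within the scatter), so a six-membered aromatic ring with a ring nitrogen and a five-membered aromatic ring with a ring oxygen and a methyl group cannot be told apart at this position by this read-out. The two groups have the same heavy-atom, donor and acceptor counts, and no measurement at hand offers an explanation for this outcome.

Going by these compounds, both groups compared at this position are aromatic rings, so it remains open whether a non-aromatic group, such as a primary amine, a carboxylic acid or a longer alkyl chain, would shift the number beyond the scatter. On these data alone, it is also open whether the same exchange would give a similar result on the core of compound 3, which carries thiophen-2-yl instead of thiophen-3-yl.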